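Working notes on compound 4: hydroxy to methoxy

A few compounds are considered here, and "the series" means these few. Any claim that something is new, unique, unknown or untested is made for them only; others in the source may bear on it.

Measured so far in a functional assay on COLO 205 cells (Homo sapiens) for inhibition, read by sulforhodamine B assay, with a stated time of 48 h, tested at 10 uM; a lower number here means a stronger effect, a higher number a weaker effect of the compound at the concentration tested:
Compound 1 `COc1cc(Cl)cc(-c2nn(-c3cccc(NC(=O)Nc4cccc(C(F)(F)F)c4)c3)cc2-c2ccncc2)c1` gives -31.2%.
Compound 2 `COc1cc(Cl)cc(-c2nn(-c3cccc(NC(=O)c4cccc(C(F)(F)F)c4)c3)cc2-c2ccncc2)c1` gives 68.5%.
Compound 3 `O=C(Nc1cccc(-n2cc(-c3ccncc3)c(-c3cc(O)cc(Cl)c3)n2)c1)c1cc(C(F)(F)F)cc(C(F)(F)F)c1` gives 38.7%.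

Compound 3 stands second highest of the three numbers: compound 2 sits higher by a margin beyond the scatter, compound 1 far lower. For the measured compounds named here, the only single-change step measured, a number 99.7 percentage points higher from compound 1 to compound 2 (beyond the scatter), concerns the carbonyl substituent, not the oxygen on the aromatic ring. Compound 4 `COc1cc(Cl)cc(-c2nn(-c3cccc(NC(=O)c4cc(C(F)(F)F)cc(C(F)(F)F)c4)c3)cc2-c2ccncc2)c1` differs from compound 3 by methyl in place of hydrogen on an oxygen on an aromatic ring. Going by the values given here, no measured pair isolates this change; compounds 2 and 3 differ here and at the carbonyl substituent at once, so their values cannot be split. Nothing in the series points to a step in this assay beyond the scatter in either direction. For compound 4 the estimate is 45%, with a range of 10% to 80%. The expected step is therefore a number 6.3 percentage points higher from compound 3 to compound 4 (within the scatter).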

Compound 4, a percentage reported as activity, at one concentration (the size of the read-out at that concentration, not a potency): 88.7%
Estimate against measurement, compound 4: 43.7 percentage points below; measured number outside the range, above it.
By their numbers in this assay, from the lowest: compound 1; then compound 3; then compound 2; then compound 4.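

In this assay the oxygen on the aromatic ring proves a sensitive place: hydroxy to methoxy gives a number 50 percentage points higher from compound 3 to compound 4 (beyond the scatter), so compound 3, with the free hydroxy, has the stronger effect. Trifluoromethyl in place of hydrogen on an aromatic carbon also matters, giving a number 20.2 percentage points higher from compound 2 to compound 4 (beyond the scatter), again towards a weaker effect. No evidence on hand accounts for either step.

Open, as far as these compounds go, is whether the hydroxy to methoxy step keeps its size with the carbonyl substituent of compound 1 or compound 2. Also open, from the compounds shown here alone, is how an amine or an ethoxy group would read at this place.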